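From pyrrolidin-1-yl to formylamino on the shared core

A few compounds are considered here, and "the series" means these few. Any claim that something is new, unique, unknown or untested is made for them only; others in the source may bear on it.

In a functional assay on the whole organism with Rattus norvegicus as the target (on this read-out higher numbers stand for an effect only at larger amounts of compound and lower numbers for an effect already at smaller amounts), compound 1 `CNc1cc(OC)c(C(=O)NC2CCN(Cc3ccccc3)C2)cc1Cl` gives 0.016 mg/kg and compound 2 `COc1cc(N2CCCC2)c(Cl)cc1C(=O)NC1CCN(Cc2ccccc2)C1` gives 0.6 mg/kg, so compound 2 holds the higher of the two numbers. Among the compounds with values here, the single measured step, a 38-fold higher number from compound 1 to compound 2 (1.57 log units; beyond the scatter), is large and comes with pyrrolidin-1-yl in place of methylamino on an aromatic carbon.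

Compound 3 `COc1cc(NC=O)c(Cl)cc1C(=O)NC1CCN(Cc2ccccc2)C1` has yet to be measured in this assay. It carries formylamino in place of pyrrolidin-1-yl on an aromatic carbon, ortho to a chloro group, meta to a methoxy group and para to a large group: formylamino in place of pyrrolidin-1-yl on an aromatic carbon. The measured step bears on this change only in part. Like methylamino, formylamino has no ring, which suggests a partial return towards compound 1 at 0.016 mg/kg. However, no measured compound carries formylamino, so a full return cannot be assumed. The expected change is a modest one towards a lower number, a 2.4-fold lower number from compound 2 to compound 3 (0.38 log units; beyond the scatter), well short of the measured step. For compound 3 the estimated value is 0.25 mg/kg, with an expected range from 0.04 mg/kg to 1.5 mg/kg.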

Compound 3, dose for half-maximal effect: 0.6 mg/kg
Beside the measured number, compound 3's estimate is 2.4-fold (0.38 log units) below it; low and high end bracket the measured number.
By their numbers in this assay, from the lowest: compound 1; then compounds 2 and 3 (each within the scatter of the next).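

In this assay, the ring is not what separates compound 2 from compound 1 at this position: the change to formylamino gives no change at the digits printed from compound 2 to compound 3 (within the scatter) even though the pyrrolidine ring is gone. Within the data shown here, what the earlier compounds could not show is that a small, ringless nitrogen group is not enough on its own, as formyl in place of methyl on the same nitrogen gives a 38-fold higher number from compound 1 to compound 3 (1.57 log units; beyond the scatter) and so leaves compound 3 no closer to compound 1 than compound 2 is. Among the three compounds, only the methylamino group of compound 1 goes with the low number, and no supporting data are available to explain why the formylamino and pyrrolidin-1-yl groups stand together.

The compounds shown leave open whether the low number is particular to methylamino or would also appear with a plain amino group, an ethylamino group or a dimethylamino group at this place. They also leave open whether an acetylamino group would stand with formylamino or take a place of its own.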